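The source may report more compounds than this note shows. Statements on the series, on what has been measured and on what is new or still open speak of the compounds shown alone.

Compound 1 `COc1ccc(C2=NN(c3ccc(S(C)(=O)=O)cc3)C(=O)CC2)cc1`: 46.7%
Compound 2 `CS(=O)(=O)c1ccc(N2N=C(c3ccc(-c4ccccc4)cc3)CCC2=O)cc1`: 6.6%
Compound 3 `CS(=O)(=O)c1ccc(N2N=C(c3ccc(Br)cc3)CCC2=O)cc1`: 10%

In a functional assay on the whole organism (strain Wistar) for inhibition, with Rattus norvegicus as the target, read by paw edema, with stated times of 30 min and 3 h, at a dose of 0.05 mmol/kg by the oral route (a higher number here means more inhibition at the dose given (going by the name of the read-out), a lower number less inhibition), compound 3 stands second highest of the three, with compound 2 nearest to it and compound 1 far above it. Compound 4 `CS(=O)(=O)c1ccc(N2N=C(c3ccc(Oc4ccccc4)cc3)CCC2=O)cc1` differs from compound 3 by phenoxy in place of bromo on an aromatic carbon. Going by the values given here, two measured steps bear on this change: a number 36.7 percentage points lower from compound 1 to compound 3 (beyond the scatter), and a number 3.4 percentage points higher from compound 2 to compound 3 (within the scatter). The entering phenoxy carries an oxygen as the methoxy of compound 1 does, yet it also carries a six-membered aromatic ring as the phenyl of compound 2 does, and compound 2 and compound 3 show similar values. The step of a number 2 percentage points higher from compound 3 to compound 4 (within the scatter) is therefore expected to stay within the scatter. The estimate for compound 4 is 12%, with a range from 0% to 32%.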

Compound 4, a percentage reported as inhibition, in the whole organism at one dose (the size of the read-out at that dose, not a potency): 50%
Compound 4: middle estimate off by 38 percentage points, on the low side, and the stated range ends below it.
By their numbers in this assay, from the lowest: compounds 2 and 3 (each within the scatter of the next); then compounds 1 and 4 (each within the scatter of the next).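

In this assay, phenoxy on this aromatic carbon gives a number 40 percentage points higher from compound 3 to compound 4 (beyond the scatter) and a number 43.4 percentage points higher from compound 2 to compound 4 (beyond the scatter), so a six-membered aromatic ring at this place does not by itself go with a low number. Phenyl in place of methyl on the oxygen gives only a number 3.3 percentage points higher from compound 1 to compound 4 (within the scatter), so the two oxygen-linked groups stand together, apart from bromo and directly attached phenyl. No evidence at hand accounts for this split. Still open, from the compounds shown here alone, is whether the oxygen itself matters, which an amine linking the same phenyl would test. Going by these compounds, how a longer chain on the oxygen, such as butoxy, would read is also open.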